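The source may hold more compounds than are shown below. What is called first, only, known or untested is meant among the compounds shown, and "the series" means these compounds.

In a functional assay on ECa-109 cells (Homo sapiens) for inhibition, read by MTT assay, with a stated time of 72 h (on this read-out higher numbers stand for weaker inhibition and lower numbers for stronger inhibition), compound 1 `Cc1ccc(-c2nc(SCc3cn(CC(=O)NC(=O)Nc4ccccn4)nn3)nc(Nc3ccc(C(C)C)cc3)c2C#N)cc1` gives 7450 nM. Compound 2 `Cc1ccc(Nc2nc(SCc3cn(CC(=O)NC(=O)Nc4ccccn4)nn3)nc(-c3ccc(C)cc3)c2C#N)cc1` reaches only the limit of this assay, > 64000 nM, which is a limit and not a number. The change is methyl in place of isopropyl on an aromatic carbon, and the step is an at least 8.5-fold higher number from compound 1 to compound 2 (0.93 log units; beyond the scatter). Compound 3 `CC(C)c1ccc(Nc2nc(SCc3cn(CC(=O)NC(=O)Nc4ccccn4)nn3)nc(-c3ccc(Cl)cc3)c2C#N)cc1` also stops at a limit, > 64000 nM. Its core differs from that of compound 1 by chloro in place of methyl on an aromatic carbon, and the step is an at least 8.5-fold higher number from compound 1 to compound 3 (0.93 log units; beyond the scatter). From the compounds shown here alone, both of these steps are set by the limit of > 64000 nM in this assay, at which 2 of the 3 values shown sit, so their true size is unknown.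

Compound 4 `Cc1ccc(Nc2nc(SCc3cn(CC(=O)NC(=O)Nc4ccccn4)nn3)nc(-c3ccc(Cl)cc3)c2C#N)cc1` is not yet measured in this assay. It differs from compound 3 by methyl in place of isopropyl on an aromatic carbon, the same change that was made from compound 1 to compound 2, where the number rose by an at least 8.5-fold higher number from compound 1 to compound 2 (0.93 log units; beyond the scatter). Since compound 3 already sits at a limit, > 64000 nM, compound 4 is expected to give 100000 nM, most likely reported again as a limit only, with a plausible range from 64000 nM to 400000 nM. The expected step is a step that the limit leaves unreadable from compound 3 to compound 4, taken to be no decrease in the number.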

Compound 4, half-maximal inhibitory concentration: 13100 nM
Estimate against measurement, compound 4: 7.6-fold (0.88 log units) above; the measured number lies below the stated range.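

In this assay, methyl in place of isopropyl now gives an at least 4.8-fold lower number from compound 3 to compound 4 (0.68 log units; beyond the scatter), so this change does not carry over from the core of compound 1 to the core of compound 3, and its direction even flips: the same change on two cores in this assay, an at least 8.5-fold higher number (0.93 log units; beyond the scatter) from compound 1 to compound 2 and an at least 4.8-fold lower number (0.68 log units; beyond the scatter) from compound 3 to compound 4, at least 41-fold (1.62 log units) apart, beyond the scatter of two such steps Chloro in place of methyl gives an at least 4.8-fold lower number from compound 2 to compound 4 (0.68 log units; beyond the scatter), and this change also flips direction between the two cores: the same change on two cores in this assay, an at least 8.5-fold higher number (0.93 log units; beyond the scatter) from compound 1 to compound 3 and an at least 4.8-fold lower number (0.68 log units; beyond the scatter) from compound 2 to compound 4, at least 41-fold (1.62 log units) apart, beyond the scatter of two such steps Within these four compounds, then, the effect of each change depends on the group at the other place, but two pairs set no rule for the wider series, and the true size of each step remains unknown: the limit of > 64000 nM in this assay, at which 2 of the 4 values shown sit.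

The compounds shown leave open whether the flip also appears when an ethyl group or a methoxy group takes the place of the isopropyl, or when a fluoro group takes the place of the chloro. Also open, from the compounds shown here alone, is how far compound 2 and compound 3 truly lie from the other two compounds.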